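Working notes: adding a methoxy group to compound 2

This account rests on a few compounds, and the source may have more. Where it says the series, first, only, none or still open, it means among the compounds named here.

- compound 1 `CCOC(=O)C(=O)Nc1nc(-c2cccc(OC)c2)cs1` gives about 20 mg/kg
- compound 2 `CCOC(=O)C(=O)Nc1nc(-c2ccc(OC)cc2)cs1` gives about 10 mg/kg

For the measured compounds named here, both values come from a functional assay on the whole organism with Rattus norvegicus as the target (on this read-out higher numbers stand for an effect only at larger amounts of compound and lower numbers for an effect already at smaller amounts), and no other measured compounds are available. Compound 2, at about 10 mg/kg, stands within the scatter of compound 1, at about 20 mg/kg, so the two cannot be ranked on these numbers.

The next compound to be read is compound 3 `CCOC(=O)C(=O)Nc1nc(-c2ccc(OC)c(OC)c2)cs1`. Its difference from compound 2 is as follows: methoxy in place of hydrogen on an aromatic carbon. In words, this is methoxy in place of hydrogen on an aromatic carbon.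

Going by the values given here, the series holds no measured pair that differs in one place, so nothing measured gives the size of such a change directly. Among the compounds with values here, the only guide is the narrow spread of the data, where compound 1 gives about 20 mg/kg and compound 2 gives about 10 mg/kg. No step beyond the scatter is therefore expected in this assay, and neither direction is favoured. The expected change is small, with a 1.2-fold higher number from compound 2 to compound 3 (0.08 log units; within the scatter) estimated. For compound 3 the estimated value is 12 mg/kg, with an expected range of 5 mg/kg to 30 mg/kg.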

Compound 3, dose for half-maximal effect: about 3 mg/kg
Estimate against measurement, compound 3: 4.0-fold (0.60 log units) above; the measured number lies below the stated range.
By their numbers in this assay, from the lowest: compound 3; then compounds 2 and 1 (each within the scatter of the next).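

In this assay methoxy in place of hydrogen, on an aromatic carbon ortho to a methoxy group and meta to a large group, gives a 3.3-fold lower number from compound 2 to compound 3 (0.52 log units; beyond the scatter) and so provides the first separation in the series that exceeds the scatter. The same kind of change read from the other single-methoxy compound gives a 6.7-fold lower number from compound 1 to compound 3 (0.82 log units; beyond the scatter) and points the same way, so compound 3, with its two methoxy groups, has the lowest number of the three, while compounds 1 and 2 cannot be ranked against each other. No measurement bearing on the reason for this step is available.

Still open, as far as these compounds go, is whether the lower number depends on the methoxy group itself or whether a hydroxy group, an ethoxy group, a fluorine atom or an amine in the same place would give a step of similar size. Also open, from the compounds shown here alone, is whether a second methoxy group would give a similar step at other places on the ring, and whether a third would lower the number further in this assay or leave it within the scatter.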